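Adding a Second Acetoxy Group to Compound 3

The compounds below may be only part of what the source reports. "The series", "measured", "known", "first", "only" and "open" are said of these compounds alone.

Measured in an assay on CHO cells for displacement of a labelled ligand from transmembrane domain-containing protein TMIGD3 (Homo sapiens); on this read-out lower numbers stand for stronger inhibition and higher numbers for weaker inhibition:
- compound 1, `CC(=O)Oc1cccc2cc(-c3cccs3)c(=O)oc12`: 2580 nM
- compound 2, `CC(=O)Oc1ccc2cc(-c3cccs3)c(=O)oc2c1OC(C)=O`: 22500 nM
- compound 3, `CC(=O)Oc1cccc2cc(-c3ccsc3)c(=O)oc12`: 1820 nM

Compound 3 gives the lowest number of the three in this assay, but its gap to compound 1 is within the scatter, so the two cannot be set apart; only compound 2 stands clearly higher than both. The two measured steps say this: a 1.4-fold lower number from compound 1 to compound 3 (0.15 log units; within the scatter) is within the scatter, while an 8.7-fold higher number from compound 1 to compound 2 (0.94 log units; beyond the scatter) is well beyond it.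

Compound 4, `CC(=O)Oc1ccc2cc(-c3ccsc3)c(=O)oc2c1OC(C)=O`, is not yet measured. It differs from compound 3 in one place: acetoxy in place of hydrogen on an aromatic carbon. This is the same change that separates compound 1 from compound 2, there made on the thiophen-2-yl series and here on the thiophen-3-yl series. Among the compounds with values here, since the swap between the two thiophene isomers moved the number only within the scatter, the step from compound 1 to compound 2 is the one measured precedent that bears on the new step, and it was a clear loss.

Compound 4 is therefore expected to show a step of about an 8.2-fold higher number from compound 3 to compound 4 (0.92 log units; beyond the scatter), in the direction of a weaker compound. The estimate for compound 4 in this assay is 15000 nM, with a range from 5000 nM to 45000 nM.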

Compound 4, inhibition constant: 3600 nM
Estimate against measurement, compound 4: 4.2-fold (0.62 log units) above; the whole stated range lies above it.
By their numbers in this assay, from the lowest: compounds 3, 1 and 4 (each within the scatter of the next); then compound 2.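

In this assay, placing an acetoxy group on the aromatic carbon ortho to the existing acetoxy group gives a 2.0-fold higher number from compound 3 to compound 4 (0.30 log units; within the scatter), so in the thiophen-3-yl series this change cannot be told apart from the scatter. The clear loss seen in the thiophen-2-yl series therefore does not carry over, and the effect of the change at this position depends on which thiophene isomer is present: the same change on two cores in this assay, an 8.7-fold higher number (0.94 log units; beyond the scatter) from compound 1 to compound 2 and a 2.0-fold higher number (0.30 log units; within the scatter) from compound 3 to compound 4, 4.4-fold (0.64 log units) apart, beyond the scatter of two such steps The thiophene swap, which could not be resolved between the compounds with a single acetoxy group, gives a 6.3-fold lower number from compound 2 to compound 4 (0.80 log units; beyond the scatter) once the second acetoxy group is present, so the two changes do not act independently in these compounds: the same change on two cores in this assay, a 1.4-fold lower number (0.15 log units; within the scatter) from compound 1 to compound 3 and a 6.3-fold lower number (0.80 log units; beyond the scatter) from compound 2 to compound 4, 4.4-fold (0.64 log units) apart, beyond the scatter of two such steps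

The compounds shown leave open whether this dependence on the thiophene isomer is specific to acetoxy or also holds for other groups at the same position, such as a hydroxyl group, a methoxy group or an amine. They also leave open whether a phenyl ring in place of either thiophene would follow the thiophen-2-yl pattern, the thiophen-3-yl pattern or neither.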